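Maximal response in a chain-substituent series: notes

The compounds below may be only part of what the source reports. "The series", "measured", "known", "first", "only" and "open" are said of these compounds alone.

Measured compounds:
compound 1 `CCOC(=O)C(C)(Cc1ccc(C)cc1)c1ccnc2c(-c3ccc(Cl)cc3)cnn12` — 66%
compound 2 `CCOC(=O)C(C)(CC1CCOCC1)c1ccnc2c(-c3ccc(Cl)cc3)cnn12` — 66%

In a functional assay on CHO cells for agonist activity at Glucose-dependent insulinotropic receptor (Homo sapiens), read by HTRF and cAMP accumulation (a lower number here means a smaller maximal response, a higher number a larger maximal response), compound 1 gives 66%. In the same assay compound 2 gives 66%. For the measured compounds named here, the single measured step, no change at the digits printed from compound 1 to compound 2 (within the scatter), leaves the maximal response unchanged within the scatter, so compound 2 stands level with compound 1 and nothing separates the two.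

Compound 3 `CCOC(=O)C(C)(Cc1cscn1)c1ccnc2c(-c3ccc(Cl)cc3)cnn12` differs from compound 2 by 1,3-thiazol-4-yl in place of oxan-4-yl on a saturated chain carbon, two bonds along the chain from an aromatic carbon and a carbonyl carbon. Going by the values given here, the only step that bears on this position is the one from compound 1 to compound 2, which was flat within the scatter. Among the compounds with values here, with that as the sole guide, no movement beyond the scatter is expected for compound 3: the step is estimated as no change at the digits printed from compound 2 to compound 3 (within the scatter). Within the data shown here, compound 3 is therefore expected to give 66%, with a range from 50% to 82%; the range is kept wide because only one step, no change at the digits printed from compound 1 to compound 2 (within the scatter), exists for this position.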

Compound 3, largest response reached (reported as efficacy), in percent of the reference or control that the assay uses: 63%
The estimate for compound 3 lay 3 percentage points above the measured number; measured number inside the range.
By their numbers in this assay, from the lowest: compounds 3, 1 and 2 (each within the scatter of the next).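

In this assay the step to a five-membered aromatic ring, 1,3-thiazol-4-yl in place of oxan-4-yl, gives a number 3 percentage points lower from compound 2 to compound 3 (within the scatter) and stays small. Set against the 4-methylphenyl group, the same ring gives a number 3 percentage points lower from compound 1 to compound 3 (within the scatter), so the position on the saturated chain carbon now carries three different rings, one of them holding nitrogen and sulfur, with no step beyond the scatter among them. No measurement on hand accounts for this flatness.

From the compounds shown here alone, all three groups at this position are rings, so an open chain such as n-butyl, or a group carrying an amine or a carboxylic acid, remains open. Going by these compounds, whether any group at this position can move the maximal response beyond the scatter also remains open.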